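Triazolyl-acetamide series: swapping the amide heteroaryl

A few compounds are considered here, and "the series" means these few. Any claim that something is new, unique, unknown or untested is made for them only; others in the source may bear on it.

Three compounds have numbers in a functional assay on BMDM cells (Mus musculus, strain C57BL/6) for inhibition, with a stated time of 2 days; a lower number here means a stronger inhibitor, a higher number a weaker inhibitor. Compound 1 `Nc1cccc(-c2cn(CC(=O)Nc3nccs3)nn2)c1` gives 1270 nM, compound 2 `O=C(Cn1cc(-c2ccccc2Cl)nn1)Nc1nccs1` gives 60 nM, and compound 3 `O=C(Cn1cc(-c2ccncc2)nn1)Nc1nccs1` gives 2 nM. Compound 2 stands second of the three: on one side there is a 21-fold lower number from compound 1 to compound 2 (1.33 log units; beyond the scatter) and on the other side a 30-fold lower number from compound 2 to compound 3 (1.48 log units; beyond the scatter), both beyond the scatter, with a 640-fold lower number from compound 1 to compound 3 (2.80 log units; beyond the scatter) spanning the whole range.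

All three measured steps change the group on the aromatic carbon of the shared core and leave the amide side untouched. Compound 4 `Cc1cc(NC(=O)Cn2cc(-c3ccccc3Cl)nn2)no1` differs from compound 2 on the other side: 5-methyl-1,2-oxazol-3-yl in place of 1,3-thiazol-2-yl on an amide-type nitrogen. Among the compounds with values here, no measured pair in this assay bears on that position, so the measured steps, large as they are, give no direction for it. Nothing here says whether the 1,3-thiazol-2-yl on the amide nitrogen carries the potency or is exchangeable.

Within the data shown here, with no guiding step, the working expectation for compound 4 in this assay is a number near that of compound 2, with a wide range allowing for loss, and a step of a 2.0-fold higher number from compound 2 to compound 4 (0.30 log units; within the scatter). The estimate for compound 4 is 120 nM, between 30 nM and 600 nM.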

Compound 4, half-maximal inhibitory concentration: > 30000 nM
Compound 4: only a limit was reported; the forecaster's own chance of this, stated with the estimate: 5%; middle value at least 250-fold (2.39 log units) from the limit.
By their numbers in this assay, from the lowest: compound 3; then compound 2; then compound 1. At a limit, above all of these: compound 4.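

Within the data shown here, replacing 1,3-thiazol-2-yl with 5-methyl-1,2-oxazol-3-yl on the amide-type nitrogen gives the first measured step at this position in this assay, and it is large: an at least 500-fold higher number from compound 2 to compound 4 (2.69 log units; beyond the scatter). With 2-chlorophenyl on the shared core, the amide side is therefore not freely exchangeable, and the potency of compound 2 depends on what sits on this nitrogen, at least as far as this one replacement goes. Going by these compounds, the value of compound 4 is a limit and not a number, so the step gives only a minimum size and the full extent of the loss stays unknown: the limit of > 30000 nM in this assay, at which 1 of the 4 values shown sits.

This one change exchanges the ring and adds a methyl together, so the compounds shown do not separate the two, and an unsubstituted 1,2-oxazol-3-yl or a 5-methyl-1,3-thiazol-2-yl would be needed to tell them apart. On these data alone, it also remains open whether the same loss holds with the pyridin-4-yl of compound 3 on the core, and whether a 1,3-thiazol-2-yl carrying an amine or a carboxylic acid would keep any of the potency.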